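Pyridine-carboxamide series: bromo to propyl at the ring carbon

A few compounds are considered here, and "the series" means these few. Any claim that something is new, unique, unknown or untested is made for them only; others in the source may bear on it.

Measured so far:
compound 1 `O=C(Nc1nn[nH]n1)c1cccc(Br)n1` – 48%
compound 2 `Cc1ccc(C(=O)Nc2nn[nH]n2)nc1` – 42%
compound 3 `Cc1ccc(C(=O)Nc2nn[nH]n2)nc1C` – 42%

In a functional assay on the whole organism for inhibition, with Rattus norvegicus as the target, at a dose of 10 mg/kg by the oral route (a higher number here means a stronger effect of the compound at the dose given, a lower number a weaker effect), compound 1 stands highest of the three numbers, yet compound 2 and compound 3 both sit within the scatter of it, so no order among them is claimed. Among the measured compounds shown here, the only single-point step, no change at the digits printed from compound 2 to compound 3 (within the scatter), adds a methyl on an aromatic carbon without any effect beyond the scatter.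

Compound 4 `CCCc1cccc(C(=O)Nc2nn[nH]n2)n1` differs from compound 1 as follows: propyl in place of bromo on an aromatic carbon. For the measured compounds named here, no measured step swaps bromo for an alkyl chain, so the nearest guide is the flat methyl step and the flat spread of the series. A change of no more than the scatter is therefore expected, a number 6 percentage points lower from compound 1 to compound 4 (within the scatter). Compound 4 is estimated at 42%, in the range 22% to 62%.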

Compound 4, a percentage reported as inhibition, in the whole organism at one dose (the size of the read-out at that dose, not a potency): 38%
The estimate for compound 4 lay 4 percentage points above the measured number, within the range that was stated.
By their numbers in this assay, from the lowest: compounds 4, 2, 3 and 1 (each within the scatter of the next).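

Propyl in place of bromo next to the ring nitrogen gives, in this assay, a number 10 percentage points lower from compound 1 to compound 4 (within the scatter). Among the compounds shown here, this is the first single-place change at this position, and replacing 1 heavy atom with 3 heavy atoms leaves the step within the scatter. No available data bear on the reason for this result.

Going by these compounds, whether an amine, a carboxylic acid or a longer chain at this position would also stay within the scatter remains open. These single-dose read-outs also leave potency open.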